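Swapping the aryl group on a thiourea nitrogen

A few compounds are considered here, and "the series" means these few. Any claim that something is new, unique, unknown or untested is made for them only; others in the source may bear on it.

Compound 3 `NC(=O)c1c(NC(=O)c2ccccc2Cl)sc2c1CCN(C(=S)Nc1ccccc1Br)C2` was tested in a functional assay on HL-60 cells (Homo sapiens) for antiproliferative activity, with a stated time of 24 h (on this read-out higher numbers stand for weaker inhibition and lower numbers for stronger inhibition), where compound 3 gives 9090 nM. Among the three measured compounds it stands second highest: compound 1 `NC(=O)c1c(NC(=O)c2ccccc2Cl)sc2c1CCNC2` gives 18600 nM, and compound 2 `NC(=O)c1c(NC(=O)c2ccccc2Cl)sc2c1CCN(Cc1ccccc1Cl)C2` gives 2900 nM. Every step seen so far concerns the amine nitrogen in the ring: a 6.4-fold lower number from compound 1 to compound 2 (0.81 log units; beyond the scatter), a 2.0-fold lower number from compound 1 to compound 3 (0.31 log units; beyond the scatter) and a 3.1-fold higher number from compound 2 to compound 3 (0.50 log units; beyond the scatter). Compound 4 `NC(=O)c1c(NC(=O)c2ccccc2Cl)sc2c1CCN(C(=S)Nc1cccnc1)C2` differs from compound 3 at a different place: pyridin-3-yl in place of 2-bromophenyl on an amide-type nitrogen. Within the data shown here, no measured step touches this part of the molecule, so the expectation rests on compound 3 alone, and a step that stays within the scatter is expected, a 1.0-fold lower number from compound 3 to compound 4 (0.00 log units; within the scatter). Compound 4 is therefore estimated at 9000 nM, with a range from 3000 nM to 27000 nM.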

Compound 4, half-maximal inhibitory concentration: 33900 nM
Estimate against measurement, compound 4: 3.8-fold (0.58 log units) below; the whole stated range lies below it.
By their numbers in this assay, from the lowest: compound 2; then compound 3; then compounds 1 and 4 (each within the scatter of the next).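

In this assay the aryl group on the thiourea nitrogen clearly matters: pyridin-3-yl in place of 2-bromophenyl gives a 3.7-fold higher number from compound 3 to compound 4 (0.57 log units; beyond the scatter) and is the first change shown at this position. With pyridin-3-yl, the group on the amine nitrogen in the ring gives a 12-fold higher number from compound 2 to compound 4 (1.07 log units; beyond the scatter) and a 1.8-fold higher number from compound 1 to compound 4 (0.26 log units; within the scatter) so this substituent no longer shows the advantage over hydrogen seen with the other two. No measured evidence bears on this result.

Still open, going by these compounds, is how much of the step follows the loss of bromine and how much the entry of the ring nitrogen. A plain phenyl group on this nitrogen would help separate the two.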